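Chloro in place of methyl on the fused core

This account rests on a few compounds, and the source may have more. Where it says the series, first, only, none or still open, it means among the compounds named here.

Three members of the series have been run in an ADME assay on microsomes from liver (Homo sapiens) for metabolic stability, using NADPH, with a stated time of 40 min, tested at 2 uM; on this read-out higher numbers stand for a longer-lived compound and lower numbers for a shorter-lived compound. Compound 1 `Fc1ccc2c(-c3ccc4ccccc4n3)c[nH]c2c1Cl` gives 0.183 h. Compound 2 `Cc1cccc2ccc(-c3c[nH]c4c(C)cccc34)nc12` gives 1.62 h. Compound 3 `Cc1c(F)ccc2c(-c3ccc4ccccc4n3)c[nH]c12` gives 0.433 h. Compound 2 stands highest of the three, with both gaps beyond the scatter; the difference between the core of compound 2 and the core of compound 3 is not broken down here.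

One single-site change is measured: chloro in place of methyl on an aromatic carbon. It gave a 2.4-fold lower number from compound 3 to compound 1 (0.37 log units; beyond the scatter), a modest step.

Compound 4 `Cc1cccc2c(-c3ccc4cccc(Cl)c4n3)c[nH]c12` is yet to be run. It differs from compound 2 by chloro in place of methyl on an aromatic carbon. This is the same kind of change as that from compound 3 to compound 1, not the same: around the earlier site the group sits ortho to a fluoro group (1 heavy atom), which the site in compound 4 lacks.

In this assay, going by the values given here, a step of about the earlier size is expected here as well, because a 2.4-fold lower number from compound 3 to compound 1 (0.37 log units; beyond the scatter) is the one measured step of this kind. For compound 4 the estimate is 0.68 h, a step of a 2.4-fold lower number from compound 2 to compound 4 (0.38 log units; beyond the scatter). Compound 4 is expected to fall between 0.35 h and 1.3 h.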

Compound 4, half-life: 1.75 h
Compound 4: the middle estimate sits 2.6-fold (0.41 log units) below what was measured; measured number above the stated range.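

In this assay, chloro in place of methyl on an aromatic carbon gives a 1.1-fold higher number from compound 2 to compound 4 (0.03 log units; within the scatter), a step that cannot be told from no change. Set beside the earlier step, the two readings of this swap cannot be separated: the same change on two cores in this assay, a 2.4-fold lower number (0.37 log units; beyond the scatter) from compound 3 to compound 1 and a 1.1-fold higher number (0.03 log units; within the scatter) from compound 2 to compound 4, 2.6-fold (0.41 log units) apart, within the scatter of two such steps. The pair therefore does not show that the change carries over from one core to another with a fixed size, nor does it show that the size depends on the core, and it leaves undecided whether the fluoro group at the earlier site plays any part.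

The compounds shown carry only methyl, chloro and fluoro groups on these cores, so it remains open how a methoxy group, a nitrile or an amine at the same site would read in this assay. Also open, as far as these compounds go, is whether a third core carrying this swap would side with the modest drop or with the flat step.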